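A propyl amide after two limits

The source may hold more compounds than are shown below. What is called first, only, known or untested is meant among the compounds shown, and "the series" means these compounds.

Measured so far in an ADME assay on Huh-7 cells (Homo sapiens) for cytotoxicity, read by a luciferase reporter and WST assay, with a stated time of 3 days; a lower number here means that less compound is tolerated, a higher number that more compound is tolerated
Compound 1 `O=C(Nc1ccc(F)cc1)c1c(NO)cc(-c2ccccc2)oc1=O` gives > 20000 nM as a limit
Compound 2 `Cc1cccc(NC(=O)c2c(NO)cc(-c3ccccc3)oc2=O)c1` gives > 20000 nM as a limit

In this assay compound 2 stands at > 20000 nM as a limit and not as a number. For the measured compounds named here, the only other value is a limit too, so the whole picture so far is the limit of > 20000 nM in this assay, at which 2 of the 2 values shown sit, and nothing finer. Compound 3 `CCCNC(=O)c1c(NO)cc(-c2ccccc2)oc1=O` carries propyl in place of 3-methylphenyl on an amide-type nitrogen, and the difference counts out as propyl in place of 3-methylphenyl on an amide-type nitrogen with the shared core unchanged. Going by the values given here, the one measured step at this nitrogen is a step that the two limits leave unreadable from compound 1 to compound 2 and it gives no size to carry over. Among the compounds with values here, no measured step puts an open chain in place of a ring-bearing group. With compound 2 at > 20000 nM as the only anchor, no step beyond the scatter is expected in this assay and another limit is the likeliest report. The expected step is a number no higher from compound 2 to compound 3 (the limit leaves the size open) as estimated here. For compound 3 the estimated half-maximal cytotoxic concentration is 20000 nM with an expected range from 9000 nM to 40000 nM.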

Compound 3, half-maximal cytotoxic concentration: > 20000 nM
Compound 3 ended at the assay's limit; the forecaster's own chance of this, stated with the estimate: 75%; the middle value sits exactly at the limit.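

In this assay compound 3 gives > 20000 nM, which is a limit and not a number. For the compounds shown here, the steps among compound 1, compound 2 and compound 3 therefore cannot be read, and no new step follows. The compounds shown leave open whether any group on the amide-type nitrogen changes the tolerated concentration, because all end at one limit: the limit of > 20000 nM in this assay, at which 3 of the 3 values shown sit.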